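The compounds below may be only part of what the source reports. "The series", "measured", "known", "first", "only" and "open" are said of these compounds alone.

In an ADME assay on the whole organism (strain Sprague-Dawley) for pharmacokinetics, with Rattus norvegicus as the target, using cassette dosing (a higher number here means faster removal of the compound, a lower number slower removal), compound 3 (`O[C@]1(Cc2cc(-c3cn[nH]c3)on2)CC[C@H](Cc2ccccc2)CC1`) gives 56.5 mL/min/kg, the higher of the two numbers available in this small series. Compound 2 (`O=c1ccc(-c2cc(C[C@]3(O)CC[C@@H](Cc4ccc(Cl)cc4)CC3)no2)c[nH]1`) gives 16.8 mL/min/kg, a lower number with a gap beyond the scatter. Compound 1 (`O=c1[nH]c2ccc(-c3cc(C[C@]4(O)CC[C@@H](Cc5ccc(Cl)cc5)CC4)no3)cc2o1`) has no number, its entry reading "not determined" (no result reported).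

The next compound to be read is compound 4 (`O[C@]1(Cc2cc(-c3cn[nH]c3)on2)CC[C@H](Cc2ccc(Cl)cc2)CC1`). Its change from compound 3 is chloro in place of hydrogen on an aromatic carbon, turning benzyl into 4-chlorobenzyl. For the measured compounds named here, no measured pair isolates this change. The nearest guide is compound 2, which carries the same 4-chlorobenzyl and gives 16.8 mL/min/kg. However, compound 2 also differs from compound 3 elsewhere in the structure, so the gap between those two values cannot be assigned to the chloro alone. Only a partial share of that gap is therefore expected to carry over to this assay here. The expected step is small and downward, estimated as a 1.5-fold lower number from compound 3 to compound 4 (0.17 log units; within the scatter), and it may not clear the scatter. For compound 4 the estimated value is 38 mL/min/kg, with an expected range of 18 mL/min/kg to 70 mL/min/kg.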

Compound 4, clearance: 11.7 mL/min/kg
Beside the measured number, compound 4's estimate is 3.2-fold (0.51 log units) above it; measured number outside the range, below it.
By their numbers in this assay, from the lowest: compounds 4 and 2 (each within the scatter of the next); then compound 3.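

In this assay, for the compounds shown here, chloro in place of hydrogen on an aromatic carbon, para to a large group, gives a 4.8-fold lower number from compound 3 to compound 4 (0.68 log units; beyond the scatter), so the turn from benzyl to 4-chlorobenzyl is now seen on its own as a step beyond the scatter, which the earlier compounds could not isolate. With 4-chlorobenzyl held constant, the five-membered aromatic ring with 2 hetero atoms in place of the six-membered aromatic ring with 1 hetero atom gives a 1.4-fold lower number from compound 2 to compound 4 (0.16 log units; within the scatter), which lies within the scatter, so this swap does not separate the two compounds in this read-out. No measurement available here bears on the reason for the size of the chloro step.

Still open, as far as these compounds go, is whether a fluoro, methyl or methoxy group at the same place would give a step of similar size, or whether the result is specific to chloro. Also open, from the compounds shown here alone, is whether the chloro step keeps its size with the six-membered ring in place, as the step rests on a single matched pair carrying the five-membered ring.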